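Sulfonyl hydrazides against indoleamine dioxygenase: carboxymethoxy for bromo

The source may report more compounds than this note shows. Statements on the series, on what has been measured and on what is new or still open speak of the compounds shown alone.

Measured so far:
compound 1 `CC(=O)Nc1ccc(S(=O)(=O)NNc2ccc(C(F)(F)F)cc2)cc1` 1610 nM
compound 2 `O=S(=O)(NNc1ccc(Br)cc1)c1ccc(Br)cc1` 85 nM

In an assay for inhibition of Indoleamine 2,3-dioxygenase 1 (Homo sapiens), read by spectrophotometry, with stated times of 1 h and 4 h (on this read-out higher numbers stand for weaker inhibition and lower numbers for stronger inhibition), compound 2 holds the lower of the two numbers, and compound 1 gives a higher one by a gap beyond the scatter. Compound 3 `O=C(O)COc1ccc(S(=O)(=O)NNc2ccc(Br)cc2)cc1` carries carboxymethoxy in place of bromo on an aromatic carbon, that is, carboxymethoxy in place of bromo on an aromatic carbon, para to a large group. For the measured compounds named here, no step with a single change connects the measured pair, so the outcome is not anchored. A weakening step is expected, a 9.4-fold higher number from compound 2 to compound 3 (0.97 log units; beyond the scatter), beyond the scatter. Compound 3 is estimated at 800 nM, within 200 nM to 3200 nM.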

Compound 3, half-maximal inhibitory concentration: 125 nM
Compound 3: middle estimate off by 6.4-fold (0.81 log units), on the high side; measured number outside the range, below it.
By their numbers in this assay, from the lowest: compounds 2 and 3 (each within the scatter of the next); then compound 1.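

At this aromatic carbon, para to a large group, carboxymethoxy in place of bromo gives a 1.5-fold higher number from compound 2 to compound 3 (0.17 log units; within the scatter) in this assay. The position thus accepts a group of 5 heavy atoms, with 1 hydrogen-bond donor and 2 hydrogen-bond acceptors, in place of bromo with 1 heavy atom and neither, with no change beyond the scatter. No supporting evidence bears on this result.

Open, as far as these compounds go, is how an amine or a longer chain ending in a carboxylic acid would read at this carbon. Also open, from the compounds shown here alone, is whether a methyl ester would match carboxymethoxy here.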